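The source may hold more compounds than are shown below. What is called first, only, known or untested is meant among the compounds shown, and "the series" means these compounds.

Measured in a functional assay on HeLa cells (Homo sapiens) for antiproliferative activity, read by MTT assay, with a stated time of 48 h; on this read-out lower numbers stand for stronger inhibition and higher numbers for weaker inhibition:
- compound 1 `CN(C)CCCn1c(N)c(-c2nc3ccccc3s2)c2nc(C#N)c(C#N)nc21`: 720 nM
- compound 2 `CN(C)CCCn1c(N)c(-c2nc3ccccc3n2C)c2nc(C#N)c(C#N)nc21`: 4320 nM
- compound 3 `CN(C)CCCCn1c(N)c(-c2nc3ccccc3n2C)c2nc(C#N)c(C#N)nc21`: 460 nM

Of these three, compound 2 gives the highest number, 4320 nM, and both other compounds lie beyond the scatter from it. The unmeasured compound 4 `CN(C)CCCn1c(N)c(-c2nc3cc(Cl)ccc3[nH]2)c2nc(C#N)c(C#N)nc21` keeps the 3-(dimethylamino)propyl group of compound 2 and differs only on an aromatic carbon, next to the ring atom that bears an amino group: 5-chloro-1H-benzimidazol-2-yl in place of 1-methyl-1H-benzimidazol-2-yl on an aromatic carbon. There, 5-chloro-1H-benzimidazol-2-yl stands in place of 1-methyl-1H-benzimidazol-2-yl.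

The measured step closest to this change is at the same place, where 1-methyl-1H-benzimidazol-2-yl replaced 1,3-benzothiazol-2-yl: a 6.0-fold higher number from compound 1 to compound 2 (0.78 log units; beyond the scatter). It shows that the group at this place can move the number beyond the scatter. The other step, a 9.4-fold lower number from compound 2 to compound 3 (0.97 log units; beyond the scatter), is a change in the chain, so it bears on compound 4 only indirectly. For the measured compounds named here, no compound with the entering group has been measured, which leaves the direction uncertain. Going by the values given here, still, the only other group measured at this place, in compound 1, gives 720 nM, so a lower number is expected in this assay. The expected change is modest, a 2.4-fold lower number from compound 2 to compound 4 (0.38 log units; beyond the scatter). The estimate for compound 4 is 1800 nM, with an expected range from 500 nM to 6000 nM.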

Compound 4, half-maximal inhibitory concentration: 16500 nM
Beside the measured number, compound 4's estimate is 9.2-fold (0.96 log units) below it; the whole stated range lies below it.
By their numbers in this assay, from the lowest: compounds 3 and 1 (each within the scatter of the next); then compound 2; then compound 4.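

The place on the shared core tolerates less than compound 1 and compound 2 alone suggested: with the 3-(dimethylamino)propyl chain held constant, the benzimidazole-type groups do not converge on the value of the 1,3-benzothiazol-2-yl group, and a 23-fold higher number from compound 1 to compound 4 (1.36 log units; beyond the scatter) is the widest step seen at this place in this assay. The two benzimidazole groups hold the same number of heavy atoms, yet exchanging them still gives a 3.8-fold higher number from compound 2 to compound 4 (0.58 log units; beyond the scatter), so the result at this place depends on more than the size of the group, and the change replaces the methyl with a ring hydrogen-bond donor while also adding a chlorine. No available evidence accounts for this loss of activity.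

The compounds shown do not separate the chlorine from the missing methyl, a question that the unchlorinated 1H-benzimidazol-2-yl group or the 5-chloro-1-methyl-1H-benzimidazol-2-yl group would address. On these data alone, it also remains open whether the longer 4-(dimethylamino)butyl chain, which gave a 9.4-fold lower number from compound 2 to compound 3 (0.97 log units; beyond the scatter), would lower the number in the same way when paired with the 5-chloro-1H-benzimidazol-2-yl group.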